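A Second Methoxy Group and Cytotoxicity in MT4 Cells

A few compounds are considered here, and "the series" means these few. Any claim that something is new, unique, unknown or untested is made for them only; others in the source may bear on it.

Compound 1 `C/C(=N\NC(N)=S)c1ccc2[nH]c(-c3ccccc3)nc2c1` opens the set. In an ADME assay on MT4 cells (Homo sapiens) for cytotoxicity, read by MTT assay, with a stated time of 96 h (on this read-out higher numbers stand for lower toxicity in this test and lower numbers for higher toxicity in this test), compound 1 gives >= 100000 nM, which is a limit of the assay rather than a number. Compound 2 `COc1ccc(-c2nc3cc(/C(C)=N/NC(N)=S)ccc3[nH]2)cc1` differs from it by methoxy in place of hydrogen on an aromatic carbon; in this assay compound 2 gives 5000 nM, and the step is an at least 20-fold lower number from compound 1 to compound 2 (1.30 log units; beyond the scatter). Compound 3 `COc1ccc(-c2nc3cc(C(C)=O)ccc3n2C2CCCCC2)cc1` is built on another core, and the difference between the two cores is not broken down here; in this assay compound 3 gives 27000 nM. Compound 4 `COc1ccc(-c2nc3cc(C(C)=O)ccc3n2C2CCCCC2)c(OC)c1` differs from compound 3 by methoxy in place of hydrogen on an aromatic carbon. This is the same kind of change as that from compound 1 to compound 2, but not the same: there the methoxy sits para to a large group, here ortho to a large group and meta to a methoxy group. A move toward lower numbers is expected because the earlier change gave an at least 20-fold lower number from compound 1 to compound 2 (1.30 log units; beyond the scatter), though a smaller one, since that earlier step starts from a limit and the place differs. The expected step is a 1.8-fold lower number from compound 3 to compound 4 (0.26 log units; within the scatter). Compound 4 is thus estimated to give 15000 nM.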

Compound 4, half-maximal cytotoxic concentration: 21000 nM
Compound 4: the middle estimate sits 1.4-fold (0.15 log units) below what was measured; the range from low to high includes it.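

In this assay, methoxy in place of hydrogen on an aromatic carbon gives a 1.3-fold lower number from compound 3 to compound 4 (0.11 log units; within the scatter), a step that cannot be told from the usual scatter. The size of the change therefore did not carry over from one core to the other: the same change on two cores in this assay, an at least 20-fold lower number (1.30 log units; beyond the scatter) from compound 1 to compound 2 and a 1.3-fold lower number (0.11 log units; within the scatter) from compound 3 to compound 4, at least 15-fold (1.19 log units) apart, beyond the scatter of two such steps. From the compounds shown here alone, this does not show whether the core or the place of the methoxy sets that gap, and the true size of the earlier step stays unknown, since compound 1 sits at a limit of the assay and not at a number: the limit of >= 100000 nM in this assay, at which 1 of the 4 values shown sits.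

The compounds shown leave open what the same change would do at other places on the shared core of compound 3 and compound 4. They also leave open how an amine, a carboxylic acid or a longer chain such as ethoxy would compare with methoxy.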